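A few compounds are considered here, and "the series" means these few. Any claim that something is new, unique, unknown or untested is made for them only; others in the source may bear on it.

In an assay on cells for displacement of a labelled ligand from adenosine receptor A1 (Homo sapiens), read by scintillation counting and radioligand binding, with a stated time of 60 min, tested at 10 uM (on this read-out higher numbers stand for more inhibition at the one concentration tested (going by the name of the read-out) and lower numbers for less inhibition), compound 1 `CN1CCN(c2nc(-c3ccc(Cl)c(Cl)c3)nc3[nH]cnc23)CC1` gives > 80%, which is a limit of the assay rather than a number. Compound 2 `Oc1cccc(-c2nc(N3CCCCC3)c3nc[nH]c3n2)c1` likewise gives > 80% in this assay, again a limit and not a number. Compound 2 therefore stands where both shown values sit, at the limit of > 80% in this assay, at which 2 of the 2 values shown sit. Compound 3 `CN1CCN(c2nc(-c3cccc(O)c3)nc3[nH]cnc23)CC1` carries 4-methylpiperazin-1-yl in place of piperidin-1-yl on an aromatic carbon. Compound 1 carries the same 4-methylpiperazin-1-yl group and reaches the limit in this assay, so no step beyond the scatter is expected. The expected step that the limit leaves unreadable from compound 2 to compound 3 is estimated to lie within the scatter. Compound 3 is thus expected to give 85%, between 70% and 95%.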

Compound 3, a percentage reported as inhibition, at one concentration (the size of the read-out at that concentration, not a potency): > 80%
Compound 3 was reported as a limit; the forecaster's own chance of this, stated with the estimate: 60%; the middle value is on the limit's open side.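

In this assay compound 3 gives > 80%, a limit and not a number. No step between compound 1, compound 2 and compound 3 can be read, because all three sit at that limit: the limit of > 80% in this assay, at which 3 of the 3 values shown sit.

The compounds shown leave open whether either replacement, of piperidin-1-yl or of 3,4-dichlorophenyl, changes inhibition at all.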